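The source may hold more compounds than are shown below. What is called first, only, known or untested is meant among the compounds shown, and "the series" means these compounds.

The series shares one core, varied at the aryl group hanging from the chain and, in one case, within the core itself. Compound 1 `NC1=NC2(CCOCC2)N(OCCCOc2cc(Cl)c(Cl)cc2Cl)C(N)=N1` gives 2360 nM in a functional assay on HL-60 cells (Homo sapiens) for antiproliferative activity, read by MTT assay, with a stated time of 72 h; a lower number here means a stronger inhibitor, a higher number a weaker inhibitor. Compound 2 `NC1=NC2(CCSCC2)N(OCCCOc2cccc(Cl)c2Cl)C(N)=N1` differs from compound 1 both in the core and in the aryl group. In this assay compound 2 gives 30 nM. Compound 3 `Cc1ccc(OCCCON2C(N)=NC(N)=NC23CCOCC3)cc1` gives 2580 nM in this assay, the highest of the three numbers; its nearest neighbour is compound 1, and compound 2 lies far below it. Within the data shown here, the one single-point step in this set, a 1.1-fold higher number from compound 1 to compound 3 (0.04 log units; within the scatter), shows that exchanging one aryl group for another on the chain oxygen left the number where it was.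

Compound 4 `NC1=NC2(CCOCC2)N(OCCCOc2ccc(Br)cc2)C(N)=N1` is not yet measured. It differs from compound 3 in one place: bromo in place of methyl on an aromatic carbon. Among the measured compounds shown here, no measured pair isolates a bromo against a methyl, so the only guide is the aryl exchange from compound 1 to compound 3, which stayed within the scatter. Compound 4 is therefore expected to give 2200 nM in this assay, within a range of 700 nM to 7000 nM. This estimate means a step of a 1.2-fold lower number from compound 3 to compound 4 (0.07 log units; within the scatter) from compound 3 to compound 4, that is, no change expected beyond the scatter.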

Compound 4, half-maximal inhibitory concentration: 310 nM
Compound 4: the middle estimate sits 7.1-fold (0.85 log units) above what was measured, outside the stated range (below it).
By their numbers in this assay, from the lowest: compound 2; then compound 4; then compounds 1 and 3 (each within the scatter of the next).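

The earlier aryl exchange had left the number unmoved, which might have suggested that this end of the chain matters little, but in this assay the exchange of a single group, bromo in place of methyl on an aromatic carbon, gives an 8.3-fold lower number from compound 3 to compound 4 (0.92 log units; beyond the scatter). The 4-bromophenyl group also stands apart from the 2,4,5-trichlorophenyl group, with a 7.6-fold lower number from compound 1 to compound 4 (0.88 log units; beyond the scatter), so among these compounds chlorines on the ring do not by themselves bring the number down, since compound 1 lies within the scatter of the methyl-bearing compound 3. Nothing shown here gives a reason for either step.

The compounds shown leave open whether a chloro, fluoro or methoxy group on that same aromatic carbon would follow bromo or methyl, and whether the bromo step would survive a longer chain between the two oxygens. Going by these compounds, compound 2 differs from compound 4 in more than one place, so how the core of compound 2 bears on the bromo step also stays open.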